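Replacing the pyrazolyl group with amino in compound 4

This account rests on a few compounds, and the source may have more. Where it says the series, first, only, none or still open, it means among the compounds named here.

Compound 3 `Cc1cc(-n2cccn2)c(S(C)(=O)=O)cc1C(=O)N=C(N)N` gives 25 nM in a functional assay for inhibition of sodium/hydrogen exchanger (Oryctolagus cuniculus) (on this read-out lower numbers stand for stronger inhibition and higher numbers for weaker inhibition), the highest of the three numbers measured, so it stands at the weak end of the set. Compound 1 `CCCSc1cc(C)c(C(=O)N=C(N)N)cc1S(C)(=O)=O` gives 6.8 nM and compound 2 `COc1cc(C)c(C(=O)N=C(N)N)cc1S(C)(=O)=O` gives 16 nM in this assay. Compound 4 `Cc1cc(N)c(S(C)(=O)=O)cc1C(=O)N=C(N)N` differs from compound 3 in one place: amino in place of 1H-pyrazol-1-yl on an aromatic carbon. The same position has been varied before: a 3.7-fold higher number from compound 1 to compound 3 (0.57 log units; beyond the scatter) and a 1.6-fold higher number from compound 2 to compound 3 (0.19 log units; within the scatter), so substituents here move this assay only modestly, and the methoxy analogue falls within the scatter of the pyrazolyl one. Amino is the smallest group tried at this position, and a small step down or none beyond the scatter is expected for compound 4, a 1.7-fold lower number from compound 3 to compound 4 (0.22 log units; within the scatter). Compound 4 is therefore estimated at 15 nM, with a range of 5 nM to 50 nM.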

Compound 4, half-maximal inhibitory concentration: 16 nM
Compound 4: middle estimate off by 1.1-fold (0.03 log units), on the low side; low and high end bracket the measured number.
By their numbers in this assay, from the lowest: compound 1; then compounds 2, 4 and 3 (each within the scatter of the next).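

Amino brings a hydrogen-bond donor where 1H-pyrazol-1-yl has none, and it has no ring, yet this assay separates neither these two groups (a 1.6-fold lower number from compound 3 to compound 4 (0.19 log units; within the scatter)) nor amino and methoxy (no change at the digits printed from compound 2 to compound 4 (within the scatter)). Only propylsulfanyl in compound 1 stands apart from amino (a 2.4-fold higher number from compound 1 to compound 4 (0.37 log units; beyond the scatter)), so compound 1 alone stands out among the four at this position. No measurement shown accounts for these steps.

Open, as far as these compounds go, is whether the lower number of compound 1 follows the sulfur or the propyl chain. Methylsulfanyl or butylsulfanyl would address that, and dimethylamino would test the amino hydrogens.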